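A Single Number to Start From: Ethyl on the Amine

This account rests on a few compounds, and the source may have more. Where it says the series, first, only, none or still open, it means among the compounds named here.

Within the data shown here, compound 1, with the structure `NC1=NS(=O)(=O)c2ccccc21`, is the only compound in this set with a numerical result. In an ADME assay on a cell-free system (plasma, Homo sapiens) for protein binding (a higher number here means a larger unbound share of the compound, a lower number a smaller unbound share), compound 1 gives 0.48, and there is no other value to set it against. Compound 2, built as `CCN1C(=O)c2ccccc2S1(=O)=O`, is also part of the series, but in this assay compound 2 returned "not determined" (no result reported), so it adds no number to the picture. Among the measured compounds shown here, with no pair of measured compounds that differ in one place, there is no comparison to draw on yet.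

The step under consideration leads from compound 1 to compound 3, whose structure is `CCNC1=NS(=O)(=O)c2ccccc21`. The structural change is ethyl in place of hydrogen on an amine nitrogen. Nothing in the data so far shows what such a change does to the unbound fraction, so the estimate rests on the structures alone. For compound 3 in this assay a modest decrease in the unbound share is expected, a step of a 1.6-fold lower number from compound 1 to compound 3 (0.20 log units; within the scatter) close to the edge of the usual scatter. Compound 3 is therefore estimated at 0.3, with a range from 0.15 to 0.48.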

Compound 3, unbound fraction in the plasma assay: 0.56
Compound 3: the middle estimate sits 1.9-fold (0.27 log units) below what was measured; the measured number lies above the stated range.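

In the plasma assay, ethyl in place of hydrogen on an amine nitrogen gives a step that cannot be told from repeat measurement, a 1.2-fold higher number from compound 1 to compound 3 (0.07 log units; within the scatter), so at this position the change leaves compound 1 and compound 3 indistinguishable in their unbound share. The same change does register in a second measurement: in a physicochemical assay for lipophilicity, at pH 7.4 (a lower number here means a more polar compound, a higher number a more lipophilic compound), compound 1 gives 0.2 and compound 3 gives 0.7. On this pair, then, greater lipophilicity with the ethyl group on this amine nitrogen comes with no matching shift in the plasma assay, something no earlier compound could show: the measured distribution coefficient of compound 1, 0.2, and of compound 3, 0.7, a number 0.50 log units higher (beyond the scatter)

This is still a single step on one core, and it sets no rule for the position. On these data alone, whether a longer chain, a ring such as cyclopropyl, or a chain ending in a carboxylic acid on the same amine nitrogen would also leave the unbound share in the plasma assay unmoved remains open, as does how far lipophilicity can climb at this position before the unbound share responds.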